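Compound 3 to compound 4: bromo in place of methoxy

The compounds below may be only part of what the source reports. "The series", "measured", "known", "first", "only" and "open" are said of these compounds alone.

In a functional assay on MGC-803 cells (Homo sapiens) for inhibition, read by MTT assay, with a stated time of 72 h (a lower number here means a stronger inhibitor, a higher number a weaker inhibitor), compound 1 `CCCc1ccc(NC(=O)C2CCN(C/C=C/c3ccccc3)CC2)cc1` gives 5210 nM and compound 2 `CC(C)c1ccc(NC(=O)C2CCN(C/C=C/c3ccccc3)CC2)cc1` gives 5200 nM. The swap of propyl for isopropyl amounts to a 1.0-fold lower number from compound 1 to compound 2 (0.00 log units; within the scatter). Compound 3 `COc1cccc(NC(=O)C2CCN(C/C=C/c3ccccc3)CC2)c1` has the highest number of the three at 37200 nM. The two steps that reach it are a 7.1-fold higher number from compound 1 to compound 3 (0.85 log units; beyond the scatter) and a 7.2-fold higher number from compound 2 to compound 3 (0.85 log units; beyond the scatter). Both replace the whole substituted phenyl, so group and place change together, and neither isolates a change at the place in question.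

Compound 4 `O=C(Nc1cccc(Br)c1)C1CCN(C/C=C/c2ccccc2)CC1` differs from compound 3 by bromo in place of methoxy on an aromatic carbon, meta to a large group. Among the measured compounds shown here, no measured compound carries bromo, and no measured step keeps that place fixed, so the guidance is indirect. For the measured compounds named here, compound 1 at 5210 nM shows only that lower numbers occur without the methoxy. A modest move to a lower number in this assay is therefore expected, covering part of that gap and not all of it. The estimated step is a 2.3-fold lower number from compound 3 to compound 4 (0.37 log units; beyond the scatter). For compound 4 the expected value is 16000 nM, with an estimated range from 6000 nM to 40000 nM.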

Compound 4, half-maximal inhibitory concentration: 9110 nM
Compound 4: middle estimate off by 1.8-fold (0.24 log units), on the high side; the range from low to high includes it.
By their numbers in this assay, from the lowest: compounds 2, 1 and 4 (each within the scatter of the next); then compound 3.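

In this assay, among the compounds shown here, the exchange on this aromatic carbon, meta to a large group, is the first step that changes one group and keeps its place fixed (a 4.1-fold lower number from compound 3 to compound 4 (0.61 log units; beyond the scatter)), which ties the high number of compound 3 to the methoxy and not to substitution at this place as such. With the 3-bromophenyl, the series no longer needs a propyl or isopropyl group to reach its lower numbers: the steps to compound 4 (a 1.8-fold higher number from compound 2 to compound 4 (0.24 log units; within the scatter) and a 1.7-fold higher number from compound 1 to compound 4 (0.24 log units; within the scatter)) both stay within the scatter, although each changes group and place together. Nothing measured here accounts for the difference between bromo and methoxy at this carbon.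

Chloro, methyl, an amine or a carboxylic acid on the same carbon would show whether the lower number is particular to bromo. They would also show whether other groups in place of the methoxy give a similar number. Going by these compounds, it also remains open whether bromo holds this number on the carbon that carries the propyl in compound 1, which would separate the effect of the group from that of its place.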